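This account rests on a few compounds, and the source may have more. Where it says the series, first, only, none or still open, it means among the compounds named here.

Of the compounds shown here, three from one series have so far been tested, and they differ from one another only at two positions on a shared core. Compound 1, with the structure `COc1cccc(Oc2ccc3c(NCCCNCc4ccco4)ccnc3c2)c1`, is the point of reference: in an ADME assay on HepG2 cells (Homo sapiens) for cytotoxicity, read by luminescence, CellTiter-Glo and ATP content, with a stated time of 72 h (on this read-out higher numbers stand for an effect only at larger amounts of compound and lower numbers for an effect already at smaller amounts), compound 1 gives 15500 nM. Compound 2, with the structure `COc1cccc(Oc2ccc3c(NCCCNCc4cccc(OC)c4O)ccnc3c2)c1`, carries 2-hydroxy-3-methoxyphenyl in place of furan-2-yl on a saturated chain carbon bound to an amine nitrogen; it changes the read-out by a 2.9-fold lower number from compound 1 to compound 2 (0.47 log units; beyond the scatter), so in this assay compound 2 gives 5300 nM. Compound 3, with the structure `Fc1ccc(Cc2ccc3c(NCCCNCc4ccco4)ccnc3c2)cc1`, keeps the (furan-2-yl)methyl group but alters the core through (4-fluorobenzyl in place of 3-methoxyphenoxy on an aromatic carbon); that step is a 2.8-fold lower number from compound 1 to compound 3 (0.44 log units; beyond the scatter), and compound 3 gives 5600 nM. The numbers of compound 2 and compound 3 lie within the usual scatter of each other, so no order can be read between them.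

Compound 4, with the structure `COc1cccc(CNCCCNc2ccnc3cc(Cc4ccc(F)cc4)ccc23)c1O`, has not yet been measured. Relative to compound 3 it carries 2-hydroxy-3-methoxyphenyl in place of furan-2-yl on a saturated chain carbon bound to an amine nitrogen, which is the same change as the one from compound 1 to compound 2, made at the same place; the two cores differ by 4-fluorobenzyl in place of 3-methoxyphenoxy on an aromatic carbon. Resting on the number that compound 3 gives, 5600 nM, and on the earlier step of a 2.9-fold lower number from compound 1 to compound 2 (0.47 log units; beyond the scatter), the step from compound 3 to compound 4 is expected to be about a 2.3-fold lower number from compound 3 to compound 4 (0.37 log units; beyond the scatter) if that change acts alike on both cores. With a single precedent, compound 4 is estimated to lie between 1000 nM and 7000 nM, with a middle value of 2400 nM.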

Compound 4, half-maximal effective concentration: 4780 nM
Compound 4: the middle estimate sits 2.0-fold (0.30 log units) below what was measured; measured number inside the range.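

On the core carrying 4-fluorobenzyl, putting 2-hydroxy-3-methoxyphenyl in place of furan-2-yl gives a 1.2-fold lower number from compound 3 to compound 4 (0.07 log units; within the scatter), while the same change on the core carrying 3-methoxyphenoxy gave a step beyond the scatter, and the two can be compared directly in this assay: the same change on two cores in this assay, a 2.9-fold lower number (0.47 log units; beyond the scatter) from compound 1 to compound 2 and a 1.2-fold lower number (0.07 log units; within the scatter) from compound 3 to compound 4, 2.5-fold (0.40 log units) apart, within the scatter of two such steps Read the other way, 4-fluorobenzyl in place of 3-methoxyphenoxy gives a 1.1-fold lower number from compound 2 to compound 4 (0.04 log units; within the scatter) when 2-hydroxy-3-methoxyphenyl is present, and the comparison with the furan-2-yl series comes out the same: the same change on two cores in this assay, a 2.8-fold lower number (0.44 log units; beyond the scatter) from compound 1 to compound 3 and a 1.1-fold lower number (0.04 log units; within the scatter) from compound 2 to compound 4, 2.5-fold (0.40 log units) apart, within the scatter of two such steps So one step stands beyond the scatter and its partner within it, yet the gap is too small to show that the change acts differently on the two cores, and equally it does not prove that the change carries over unchanged, since these two comparisons rest on the same four compounds and are not independent checks.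

On these data alone, whether a plain phenyl or a 2-hydroxyphenyl on the same chain carbon would follow either step remains open, so the part of 2-hydroxy-3-methoxyphenyl that matters cannot be named. A longer chain linking the core to the amine, or an amide on the shared core, is likewise untested here for how it would affect the transfer of this change.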